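The compounds below may be only part of what the source reports. "The series", "measured", "known", "first", "only" and "open" are said of these compounds alone.

Compound 2 `CNCc1c(OC)cc(Oc2cccc(Nc3ccccc3)c2)cc1OC` gives 8930 nM in a functional assay on HCT-15 cells (Homo sapiens) for inhibition, read by MTT assay, with a stated time of 72 h (on this read-out higher numbers stand for weaker inhibition and lower numbers for stronger inhibition), the highest of the three numbers shown, though all three lie within the scatter of one another: compound 1 `CCN1CCN(Cc2c(OC)cc(Oc3cccc(Nc4ccccc4)c3)cc2OC)CC1` gives 5090 nM and compound 3 `COc1cc(Oc2cccc(Nc3ccccc3)c2)cc(OC)c1CNCc1ccc(C)cc1` gives 5400 nM. Compound 4 `COc1cc(Oc2cccc(Nc3ccccc3)c2)cc(OC)c1CNCc1ccc(F)cc1` differs from compound 2 by 4-fluorophenyl in place of hydrogen on a saturated chain carbon bound to an amine nitrogen. Going by the values given here, the closest precedent is the step of a 1.7-fold lower number from compound 2 to compound 3 (0.22 log units; within the scatter), where 4-methylphenyl entered at the same place; the steps of a 1.8-fold higher number from compound 1 to compound 2 (0.24 log units; within the scatter) and a 1.1-fold higher number from compound 1 to compound 3 (0.03 log units; within the scatter) likewise stayed within the scatter. Nothing in these numbers points to a change beyond the scatter, so compound 4 is expected to show a step of a 1.5-fold lower number from compound 2 to compound 4 (0.19 log units; within the scatter). The estimate for compound 4 in this assay is 5800 nM, with a range from 2500 nM to 13000 nM.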

Compound 4, half-maximal inhibitory concentration: 3640 nM
For compound 4 the middle estimate is 1.6-fold (0.20 log units) above the measured one; measured number inside the range.
By their numbers in this assay, from the lowest: compounds 4, 1, 3 and 2 (each within the scatter of the next, the first and the last beyond it).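

In this assay, the entry of 4-fluorophenyl on a saturated chain carbon bound to an amine nitrogen gives a 2.5-fold lower number from compound 2 to compound 4 (0.39 log units; beyond the scatter) and is the first change shown to pass the scatter, which 4-methylphenyl at the same place did not. Fluoro in place of methyl on an aromatic carbon gives only a 1.5-fold lower number from compound 3 to compound 4 (0.17 log units; within the scatter) and (4-fluorobenzyl)amino in place of 4-ethylpiperazin-1-yl gives a 1.4-fold lower number from compound 1 to compound 4 (0.15 log units; within the scatter) as well. No measurement at hand accounts for the modest step. Still open, on these data alone, is how chloro on that aromatic carbon, a carboxylic acid there, or a longer chain carrying the 4-fluorophenyl would read.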